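This account rests on a few compounds, and the source may have more. Where it says the series, first, only, none or still open, it means among the compounds named here.

Of the compounds shown here, three have been measured so far in an assay for inhibition of LL-diaminopimelate aminotransferase, chloroplastic (Arabidopsis thaliana), tested at 10 uM; a higher number here means more inhibition at the concentration tested (going by the name of the read-out), a lower number less inhibition. Compound 1, `CCOC(=O)C1=C(Nc2ccc([N+](=O)[O-])cc2)S/C(=C\c2ccc(N(C)C)cc2)C1=O`, gives 19% in this assay. Compound 2, `C/C(=N\NC(=O)c1cc(C2CC2)n[nH]1)c1ccc(C)cc1`, gives 14% in this assay, and compound 3, `COc1ccc(/C=C2/C=C(c3ccccc3)OC2=O)c(OC)c1`, gives 14% in this assay. Compound 1 therefore holds the highest of the three numbers, but its gap to compound 2 and its gap to compound 3 both lie within the usual scatter of repeated measurements, so the three compounds read much alike.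

Compound 4, `CCOC(=O)C1=C(Nc2ccc(OC)cc2)S/C(=C\c2ccc(N(C)C)cc2)C1=O`, has not yet been measured. It differs from compound 1 in a single place: methoxy in place of nitro on an aromatic carbon. Within the data shown here, no pair of measured compounds that differ in only one place is available, so there is no comparable step to lean on. With nothing in the measured set to show how this exchange moves the read-out, the expected step in this assay is a number 3 percentage points lower from compound 1 to compound 4 (within the scatter), small and with no direction favoured beyond the scatter. Compound 4 is estimated to give 16% in this assay, within a range from 4% to 32%.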

Compound 4, a percentage reported as inhibition, at one concentration (the size of the read-out at that concentration, not a potency): 22%
For compound 4 the middle estimate is 6 percentage points below the measured one; the range from low to high includes it.
By their numbers in this assay, from the lowest: compounds 2, 3, 1 and 4 (each within the scatter of the next).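

Among these compounds, the exchange of nitro for methoxy on this aromatic carbon, read in this assay, gives a number 3 percentage points higher from compound 1 to compound 4 (within the scatter) and is the first single-place comparison available. It shows that the (4-nitrophenyl)amino and (4-methoxyphenyl)amino versions of this core read alike, although the two groups differ in their heavy atoms and hydrogen-bond acceptors. Nothing at hand explains this result or shows what either group contributes.

From the compounds shown here alone, whether a different group on the same aromatic carbon, such as an amine or a carboxylic acid, would shift the number beyond the scatter remains open. A single pair also leaves open whether the same exchange would read alike on a different core, and whether any change at this position matters in this assay.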